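From Trifluoromethyl to Difluoro on a Sulfonyl Sulfur

The compounds below may be only part of what the source reports. "The series", "measured", "known", "first", "only" and "open" are said of these compounds alone.

Of the compounds shown here, two with the same core have so far been measured in an ADME assay on microsomes from liver (Mus musculus) for metabolic stability, read by LC-MS, with a stated time of 30 min, tested at 1 uM (a lower number here means that less of the compound is left, a higher number that more of the compound is left), and their numbers lie within the scatter of each other. Compound 1 (`O=C(NCc1ccc(S(=O)(=O)c2cccc(F)c2)cc1)c1cc2cnccc2[nH]1`) gives 44% in this test, and compound 2 (`O=C(NCc1ccc(S(=O)(=O)c2ccccc2C(F)(F)F)cc1)c1cc2cnccc2[nH]1`) gives 41% in the same test, so compound 2 stands level with compound 1.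

Compound 3 (`O=C(NCc1ccc(S(=O)(=O)c2cc(F)cc(F)c2)cc1)c1cc2cnccc2[nH]1`) has not yet been measured. It carries 3,5-difluorophenyl in place of 2-(trifluoromethyl)phenyl on a sulfonyl sulfur. Within the data shown here, only one measured step bears on this change, and it touches the same place: a number 3 percentage points lower from compound 1 to compound 2 (within the scatter) on replacing 3-fluorophenyl with 2-(trifluoromethyl)phenyl. Among the measured compounds shown here, compound 3 keeps a fluorinated phenyl there, as compound 1 does, but no measured compound yet carries 3,5-difluorophenyl, and a single step is thin evidence.

No step beyond the scatter is therefore expected in this assay and the expected step is a number 2 percentage points higher from compound 2 to compound 3 (within the scatter) at most a small one. Compound 3 is estimated at 43% with an expected range of 31% to 55% in this test.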

Compound 3, percent of the compound remaining: 63%
Compound 3: the middle estimate sits 20 percentage points below what was measured, outside the stated range (above it).
By their numbers in this assay, from the lowest: compounds 2 and 1 (each within the scatter of the next); then compound 3.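

In this assay, among these compounds, replacing 2-(trifluoromethyl)phenyl with 3,5-difluorophenyl on the sulfonyl sulfur gives a number 22 percentage points higher from compound 2 to compound 3 (beyond the scatter) and is the first step at this place to pass beyond the scatter, which shows that the group on this sulfur can move the read-out after all. A single change also suffices, since fluoro in place of hydrogen on an aromatic carbon gives a number 19 percentage points higher from compound 1 to compound 3 (beyond the scatter) and sets compound 3 apart from compound 1, while compound 1 and compound 2 remain level with each other. Nothing shown here explains the rise.

The compounds shown leave open whether the rise is particular to 3,5-difluorophenyl or would also appear with chloro, methoxy, nitrile or amine groups on that aromatic ring. From the compounds shown here alone, whether the same exchange would hold on a different core, and how compound 3 would read in any test other than this assay, also remains unknown.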